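The source may report more compounds than this note shows. Statements on the series, on what has been measured and on what is new or still open speak of the compounds shown alone.

Measured compounds in a functional assay on T47D cells (Homo sapiens) for cytotoxicity, read by CCK-8 assay and cell counting, with a stated time of 2 days; a higher number here means a weaker inhibitor, a lower number a stronger inhibitor:

compound 1, `Oc1cccc(-c2cc(-c3ccc(Cl)cc3)nc(-c3cccs3)c2)c1`, gives 10500 nM
compound 2, `Oc1ccc(-c2cc(-c3ccc(Cl)cc3)nc(-c3ccsc3)c2)cc1`, gives 5490 nM
compound 3, `Oc1cccc(-c2cc(-c3cccs3)nc(-c3ccccc3Cl)c2)c1`, gives 3990 nM

The three compounds share a core that carries a hydroxyphenyl group, a thiophene ring and a chlorophenyl group. Compound 1 and compound 3 differ in one place only, described as 2-chlorophenyl in place of 4-chlorophenyl on an aromatic carbon. That change gave a 2.6-fold lower number from compound 1 to compound 3 (0.42 log units; beyond the scatter). Compound 2 differs from compound 1 in more than one place, so the difference between the two cores is not broken down here; the values of compound 2 and compound 1 lie within the scatter of each other, as do the values of compound 2 and compound 3, so no order among them is drawn.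

The unmeasured compound 4, `Oc1ccc(-c2cc(-c3ccsc3)nc(-c3ccccc3Cl)c2)cc1`, stands to compound 2 as compound 3 stands to compound 1: 2-chlorophenyl in place of 4-chlorophenyl on an aromatic carbon. The surroundings are not the same word for word, since in compound 1 the place is meta to a 3-hydroxyphenyl group and meta to a thiophen-2-yl group, whereas in compound 2 it is meta to a 4-hydroxyphenyl group and meta to a thiophen-3-yl group, so this is the same kind of change rather than the same change. The expectation rests on a single earlier instance, so it is held loosely. Because compound 2 gives 5490 nM and the earlier instance gave a 2.6-fold lower number from compound 1 to compound 3 (0.42 log units; beyond the scatter), a step of about a 2.2-fold lower number from compound 2 to compound 4 (0.34 log units; beyond the scatter) is expected in this assay. Compound 4 is therefore estimated at 2500 nM, with a likely range from 1200 nM to 6000 nM.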

Compound 4, half-maximal inhibitory concentration: 6110 nM
Beside the measured number, compound 4's estimate is 2.4-fold (0.39 log units) below it; the measured number lies above the stated range.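

On the core of compound 2, 2-chlorophenyl in place of 4-chlorophenyl gave a 1.1-fold higher number from compound 2 to compound 4 (0.05 log units; within the scatter) in this assay, so the lower number seen for this change on the core of compound 1 did not carry over to this second core. For the compounds shown here, the change therefore did not act alike on the two cores, and the gap between the two steps is larger than their scatter can account for: the same change on two cores in this assay, a 2.6-fold lower number (0.42 log units; beyond the scatter) from compound 1 to compound 3 and a 1.1-fold higher number (0.05 log units; within the scatter) from compound 2 to compound 4, 2.9-fold (0.47 log units) apart, beyond the scatter of two such steps This does not show which difference between the cores goes with the gap, since the core of compound 1 carries a 3-hydroxyphenyl group and a thiophen-2-yl group, the core of compound 2 carries a 4-hydroxyphenyl group and a thiophen-3-yl group, and each core supplies only one pair.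

Still open, as far as these compounds go, is how the same change would behave on a core joining the 3-hydroxyphenyl group with the thiophen-3-yl group, or the 4-hydroxyphenyl group with the thiophen-2-yl group, either of which would separate the two differences. Also open, from the compounds shown here alone, is whether a bromophenyl group in place of the chlorophenyl group, or a methoxyphenyl or aminophenyl group in place of the hydroxyphenyl group, would give steps that agree or differ between the cores.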